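Mirror-image change at the chain carbon of compound 2

The source may report more compounds than this note shows. Statements on the series, on what has been measured and on what is new or still open speak of the compounds shown alone.

In an assay on HEK293 cells for binding affinity to Gonadotropin-releasing hormone receptor (Homo sapiens), read by radioligand binding (a higher number here means a weaker inhibitor, a lower number a stronger inhibitor), compound 1 `COc1cccc(-c2c(C)n(Cc3c(F)cccc3F)c(=O)n(C[C@@H](C3CCCCC3)N(C)C)c2=O)c1F` gives 4.1 nM, and compound 2 `COc1cccc(-c2c(C)n(Cc3c(F)cccc3F)c(=O)n(C[C@@H](N)C3CCCCC3)c2=O)c1F` gives 46 nM. Going by the values given here, compound 2 therefore stands at the weaker end of the two numbers measured so far, the only comparison being an 11-fold higher number from compound 1 to compound 2 (1.05 log units; beyond the scatter). Compound 3 `COc1cccc(-c2c(C)n(Cc3c(F)cccc3F)c(=O)n(C[C@H](N)C3CCCCC3)c2=O)c1F` is the not yet measured partner of compound 2: the two compounds have the same atoms and bonds and differ only in configuration as drawn: 1 of 1 stereo elements differ; a stereocentre at a saturated chain carbon is drawn S in compound 2 and R in compound 3. Among the compounds with values here, no measured step concerns a change of configuration alone; the one step available, an 11-fold higher number from compound 1 to compound 2 (1.05 log units; beyond the scatter), swaps one group for another and says nothing about which configuration is favoured. Such a change can leave the number unchanged or move it in either direction. Because compound 2 gives 46 nM for one arrangement only, the expectation for compound 3 is a moderately higher number in this assay, a 3.3-fold higher number from compound 2 to compound 3 (0.51 log units; beyond the scatter), with wide uncertainty. Compound 3 is estimated at 150 nM in this assay, in the range 20 nM to 1500 nM.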

Compound 3, inhibition constant: 6.5 nM
Beside the measured number, compound 3's estimate is 23-fold (1.36 log units) above it; measured number below the stated range.
By their numbers in this assay, from the lowest: compounds 1 and 3 (each within the scatter of the next); then compound 2.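

Configuration at this chain carbon matters in this assay: with the amino group in place, changing the stereocentre from S to R gives a 7.1-fold lower number from compound 2 to compound 3 (0.85 log units; beyond the scatter). This gap belongs to the stereocentre alone, because nothing else in the structure changes: the fact that compounds 2 and 3 differ only in the configuration as drawn. The earlier step made amino look like a clear loss against dimethylamino, but that reading does not hold for the R form, which shows a 1.6-fold higher number from compound 1 to compound 3 (0.20 log units; within the scatter), so an amino group at this carbon need not go with a weaker number.

The compounds shown leave open whether the mirror-image form of compound 1 would show a gap of similar size. They also leave open how a methylamino group on this carbon, or a phenyl ring in place of the cyclohexyl ring, would fare in either configuration.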